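A few compounds are considered here, and "the series" means these few. Any claim that something is new, unique, unknown or untested is made for them only; others in the source may bear on it.

Compound 1 `COc1ccc(F)cc1CNCCCNc1ccnc2cc(Cc3cc(C)cc(C)c3)ccc12`: 9.47
Compound 2 `FC(F)(F)c1ccc(-c2ccc3c(NCCCNCc4ccco4)ccnc3c2)cc1`: 9.47

In a physicochemical assay for acid dissociation, compound 1 stands level with compound 2; the two values lie within the scatter of each other, so no order can be read between them. Compound 3 `COc1ccc(F)cc1CNCCCNc1ccnc2cc(Cc3ccccc3)ccc12` has not yet been measured. It differs from compound 1 in one place: phenyl in place of 3,5-dimethylphenyl on a saturated chain carbon bound to an aromatic carbon. For the measured compounds named here, no measured pair differing in a single place is available to size this kind of change, so the step from compound 1 is expected to be none beyond the scatter, a number 0.02 log units lower from compound 1 to compound 3 (within the scatter). Compound 3 is therefore estimated at 9.45, with a range from 9.15 to 9.75.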

Compound 3, acid dissociation constant: 9.47
Compound 3: the middle estimate sits 0.02 log units below what was measured, within the range that was stated.
By their numbers in this assay, from the lowest: compounds 1, 2 and 3 (each within the scatter of the next).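

In this assay, putting phenyl in place of 3,5-dimethylphenyl on a saturated chain carbon bound to an aromatic carbon gives no change at the digits printed from compound 1 to compound 3 (within the scatter) for this single swap. For the compounds shown here, this is the first pair differing in one place, and it shows that going from 8 heavy atoms to 6 in this group, with the carbon-only aromatic ring kept, has no readable effect on this number. Nothing measured here offers an explanation for the result. Still open, going by these compounds, is whether a group of another kind at this place, such as an amine or a carboxylic acid, would shift the value beyond the scatter.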